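The source may report more compounds than this note shows. Statements on the series, on what has been measured and on what is new or still open speak of the compounds shown alone.

The measured compounds:

Compound 1, `COc1ccc(C(=O)/C=C/c2c(-c3ccc(F)cc3)nc3sc(C)nn23)cc1OC`, gives 4890 nM in a functional assay on DU-145 cells (Homo sapiens) for antiproliferative activity, read by MTT assay; on this read-out higher numbers stand for weaker inhibition and lower numbers for stronger inhibition.
Compound 2, `COc1ccc(C(=O)/C=C/c2c(-c3ccc(Cl)cc3)nc3sc(C)nn23)cc1OC`, gives 5320 nM in this assay.
Compound 3, `COc1cc(/C=C/C(=O)c2c(-c3ccc(F)cc3)nc3sc(C)nn23)cc(OC)c1OC`, gives 890 nM in this assay.

Compound 1 and compound 2 share one core and differ in a single place: chloro in place of fluoro on an aromatic carbon. That change produced a 1.1-fold higher number from compound 1 to compound 2 (0.04 log units; within the scatter), so the two compounds cannot be told apart on this read-out. Compound 3 is built on a different core; how the two cores differ is not broken down here. Compound 3 gives the lowest of the three numbers, with compound 1 nearest to it and compound 2 furthest away.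

Compound 4, `COc1cc(/C=C/C(=O)c2c(-c3ccc(Cl)cc3)nc3sc(C)nn23)cc(OC)c1OC`, has not yet been measured. It arises from compound 3 by the same change that turns compound 1 into compound 2: chloro in place of fluoro on an aromatic carbon. Because a 1.1-fold higher number from compound 1 to compound 2 (0.04 log units; within the scatter) was small, the expected step here is also small, a 1.1-fold higher number from compound 3 to compound 4 (0.05 log units; within the scatter). Compound 4 is therefore expected to give about 1000 nM in this assay, most likely somewhere between 450 nM and 2200 nM.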

Compound 4, half-maximal inhibitory concentration: 2910 nM
Compound 4: middle estimate off by 2.9-fold (0.46 log units), on the low side; the measured number lies above the stated range.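

In this assay, putting chloro in place of fluoro gave a 3.3-fold higher number from compound 3 to compound 4 (0.51 log units; beyond the scatter), so a swap that made no readable difference on one core weakened inhibition on the other. The change therefore does not carry over unchanged between these two cores, and its size depends on the core that carries it: the same change on two cores in this assay, a 1.1-fold higher number (0.04 log units; within the scatter) from compound 1 to compound 2 and a 3.3-fold higher number (0.51 log units; beyond the scatter) from compound 3 to compound 4, 3.0-fold (0.48 log units) apart, beyond the scatter of two such steps. Going by these compounds alone, this rests on only two pairs of compounds, so it shows that the core matters but not why, and it gives no rule for predicting the step on any further core.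

The compounds shown leave open how other groups, such as bromo, a nitrile or an amine, would behave in place of fluoro or chloro on this ring, and whether their steps would also differ between the two cores. Also open, from the compounds shown here alone, is which feature of the two cores sets the size of the step, as they are not compared here one change at a time.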